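The source may report more compounds than this note shows. Statements on the series, on what has been measured and on what is new or still open speak of the compounds shown alone.

Measured in an ADME assay on HepG2 2.2.15 cells (Homo sapiens) for cytotoxicity; on this read-out higher numbers stand for lower toxicity in this test and lower numbers for higher toxicity in this test:
- compound 1 `O=C(CN1C(=O)c2ccccc2C1=O)OCCc1c(-c2ccccc2Cl)c2cc(Cl)ccc2[nH]c1=O`: 960000 nM
- compound 2 `O=C(COc1ccccc1)OCCc1c(-c2ccccc2Cl)c2cc(Cl)ccc2[nH]c1=O`: 81000 nM
- compound 3 `COc1cccc(/C=C/C(=O)OCCc2c(-c3ccccc3Cl)c3cc(Cl)ccc3[nH]c2=O)c1`: > 1300000 nM (a limit)

Compound 3 is known only through a limit, (the limit of > 1300000 nM in this assay, at which 1 of the 3 values shown sits). Compound 4 `C/C=C(\C)C(=O)OCCc1c(-c2ccccc2Cl)c2cc(Cl)ccc2[nH]c1=O` carries 1-methylprop-1-en-1-yl in place of 2-(3-methoxyphenyl)ethenyl on a carbonyl carbon. The closest guide is an at least 16-fold higher number from compound 2 to compound 3 (1.20 log units; beyond the scatter), a large step. a 12-fold lower number from compound 1 to compound 2 (1.07 log units; beyond the scatter) is also large, whereas an at least 1.3-fold higher number from compound 1 to compound 3 (0.13 log units; that floor lies within the scatter) stays within the scatter. Going by the values given here, all three measured compounds keep a six-membered aromatic ring in this group, and compound 4 has no ring there, so no measured step matches this change. A moderately lower number is expected, as an at least 4.3-fold lower number from compound 3 to compound 4 (0.63 log units; beyond the scatter). For compound 4, the estimated value is 300000 nM, with an expected range of 60000 nM to 1300000 nM.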

Compound 4, half-maximal cytotoxic concentration: 350000 nM
For compound 4 the middle estimate is 1.2-fold (0.07 log units) below the measured one; the measured number falls inside the stated range.
By their numbers in this assay, from the lowest: compound 2; then compound 4; then compound 1. At a limit, above all of these: compound 3.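

Without any ring in this group, compound 4 still falls among the ring-bearing compounds, giving a 4.3-fold higher number from compound 2 to compound 4 (0.64 log units; beyond the scatter) and a 2.7-fold lower number from compound 1 to compound 4 (0.44 log units; beyond the scatter). Replacing 2-(3-methoxyphenyl)ethenyl with 1-methylprop-1-en-1-yl gives an at least 3.7-fold lower number from compound 3 to compound 4 (0.56 log units; beyond the scatter). Compound 3 is only a limit, so that step is a floor: the limit of > 1300000 nM in this assay, at which 1 of the 4 values shown sits.

With a single ringless group, the effects of losing the ring and of shrinking the group remain inseparable. As far as these compounds go, how a saturated butyl chain or a group carrying an amine would read on this carbonyl carbon stays open.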